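A Smaller Group on the Ring Amine of Compound 3

The source may report more compounds than this note shows. Statements on the series, on what has been measured and on what is new or still open speak of the compounds shown alone.

Compound 3 `N#Cc1cccc(COc2ccc(-c3cc(CN4CCN(c5ccc(C(F)(F)F)cn5)CC4)no3)cc2)c1` gives 1400 nM in a functional assay on MCF7 cells (Homo sapiens) for antiproliferative activity, read by sulforhodamine B assay, with a stated time of 72 h (a lower number here means a stronger inhibitor, a higher number a weaker inhibitor), the second highest of the three numbers: compound 1 `FC(F)(F)c1ccc(CN2CCN(Cc3cc(-c4ccc(OCc5ccc(Cl)cc5)cc4)on3)CC2)cc1` gives 6700 nM, a higher number, while compound 2 `N#Cc1ccc(COc2ccc(-c3cc(CN4CCN(Cc5ccc(C(F)(F)F)cc5)CC4)no3)cc2)cc1` gives 100 nM, a much lower one. Going by the values given here, the only measured step, a 67-fold lower number from compound 1 to compound 2 (1.83 log units; beyond the scatter), concerns a change on an aromatic carbon elsewhere and leaves the ring amine untouched. Compound 4 `N#Cc1cccc(COc2ccc(-c3cc(CN4CCN(CC5CC5)CC4)no3)cc2)c1` differs from compound 3 by cyclopropylmethyl in place of 5-(trifluoromethyl)pyridin-2-yl on an amine nitrogen in a ring. Among the compounds with values here, no measured step bears on this change, and compound 2 and compound 3 differ in more than one place, so they give no clean guide. Compound 4 is therefore expected to show a step of a 1.8-fold higher number from compound 3 to compound 4 (0.25 log units; within the scatter). The estimate for compound 4 is 2500 nM, within 600 nM to 10000 nM.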

Compound 4, half-maximal inhibitory concentration: 3500 nM
The estimate for compound 4 lay 1.4-fold (0.15 log units) below the measured number; measured number inside the range.
By their numbers in this assay, from the lowest: compound 2; then compound 3; then compounds 4 and 1 (each within the scatter of the next).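

Going by these compounds alone, this is the first step read at the amine nitrogen in a ring, and in this assay it is modest: a 2.5-fold higher number from compound 3 to compound 4 (0.40 log units; beyond the scatter). Cyclopropylmethyl, with 4 heavy atoms and a three-membered non-aromatic ring, replaces 5-(trifluoromethyl)pyridin-2-yl, with 10 heavy atoms and a six-membered aromatic ring, so this large change in the group moves the number measurably but only modestly. No evidence bearing on the reason for this step is available. Going by these compounds, whether a smaller methyl or an acetyl on this nitrogen would give a similar number remains open.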